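Three limits and one untested change

A few compounds are considered here, and "the series" means these few. Any claim that something is new, unique, unknown or untested is made for them only; others in the source may bear on it.

Compound 1 `O=C(NC[C@@H]1[C@H]2CN(C(=O)/C=C/c3cc(Cl)cc(Cl)c3)C[C@@H]12)c1ccc2[nH]c(=O)oc2c1` gives < 1 ug/mL in a physicochemical assay for solubility, with a stated time of 24 h, at pH 4.5 (a lower number here means a less soluble compound, a higher number a more soluble compound), as a limit and not a number. Compound 2 `O=C(NC[C@@H]1[C@H]2CN(C(=O)CCc3cc(Cl)cc(Cl)c3)C[C@@H]12)c1ccc2[nH]c(=O)oc2c1` gives < 1 ug/mL in this assay and this too is a limit. Compound 3 `CC(OC(=O)N1C[C@@H]2[C@@H](CNC(=O)c3ccc4[nH]c(=O)oc4c3)[C@@H]2C1)c1cc(Cl)cc(Cl)c1` gives < 1 ug/mL as a limit as well. Compound 3 thus stands at the limit of < 1 ug/mL in this assay, at which 3 of the 3 values shown sit, with no rank among the three.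

The change to compound 4 `Cc1ccc(COC(=O)N2C[C@@H]3[C@@H](CNC(=O)c4ccc5[nH]c(=O)oc5c4)[C@@H]3C2)nc1` is a group of 8 heavy atoms (7 carbon, 1 nitrogen; one six-membered aromatic ring with 1 hetero atom) in place of a group of 10 heavy atoms (8 carbon, 2 chlorine; one six-membered aromatic ring of carbon only), on an oxygen next to a carbonyl group and it brings in (5-methylpyridin-2-yl)methyl while both chlorine atoms leave. For the measured compounds named here, three measured steps bear on it, and none gives a size: a step that the two limits leave unreadable from compound 1 to compound 2 then a step that the two limits leave unreadable from compound 1 to compound 3 and finally a step that the two limits leave unreadable from compound 2 to compound 3 in the same way. The expectation therefore rests on the structural change alone, starting from compound 3 with its limit of < 1 ug/mL as the only anchor. A rise is expected, though with wide uncertainty, and it may still end at the limit. The expected step is an at least 6.0-fold higher number from compound 3 to compound 4 (0.77 log units; beyond the scatter) in this assay as a rough estimate. The estimated value for compound 4 is 6 ug/mL with 1 ug/mL to 40 ug/mL as the expected range.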

Compound 4, solubility: 66 ug/mL
Beside the measured number, compound 4's estimate is 11-fold (1.04 log units) below it; measured number above the stated range.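

For the compounds shown here, with (5-methylpyridin-2-yl)methyl on an oxygen next to a carbonyl group, compound 4 gives the first readable number in this assay, a large step: an at least 66-fold higher number from compound 3 to compound 4 (1.81 log units; beyond the scatter). The steps against the other two limit compounds are as large, an at least 66-fold higher number from compound 2 to compound 4 (1.81 log units; beyond the scatter) and an at least 66-fold higher number from compound 1 to compound 4 (1.81 log units; beyond the scatter), though there the group that changes sits on a carbonyl carbon. The earlier compounds could show no difference at all, so this is the first sign that the group at this place can move the read-out off the floor that the others share: the limit of < 1 ug/mL in this assay, at which 3 of the 4 values shown sit.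

Compound 4 changes the aromatic ring, the methyl group and both chlorine atoms at once, so the share of each stays unresolved. As far as these compounds go, how an amine, a carboxylic acid or a longer chain at this place would read remains open.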